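Series notes: from compound 2 toward compound 4

The source may hold more compounds than are shown below. What is called first, only, known or untested is meant among the compounds shown, and "the series" means these compounds.

compound 1, `COc1cccc(OCCC(C)(C)C)c1C(=O)/C=C/c1ccc(O)cc1`, gives > 30000 nM in a functional assay on HCT-15 cells (Homo sapiens) for antiproliferative activity, read by sulforhodamine B assay; a higher number here means a weaker inhibitor of growth, a lower number a stronger inhibitor of growth; this is a limit of the assay, not a number.
compound 2, `O=C(/C=C/c1ccc(O)cc1)c1c(O)cccc1OCCC1CCCC1`, gives 3310 nM in this assay.
compound 3, `CC(C)(C)CCOc1cccc(O)c1C(=O)/C=C/c1ccc(C(=O)O)cc1`, gives 2170 nM in this assay.

Compound 2 holds the higher of the two numbers in this assay, but its nearest neighbour, compound 3, lies within the usual scatter, so no order between the two is claimed. For compound 1 there is only (the limit of > 30000 nM in this assay, at which 1 of the 3 values shown sits). Compound 4, `O=C(/C=C/c1ccc(O)cc1)c1c(O)cccc1OCCC1CCCCC1`, is not yet measured. Against compound 2 the difference is cyclohexyl in place of cyclopentyl on a saturated chain carbon, two bonds along the chain from an oxygen on an aromatic ring. For the measured compounds named here, no measured pair shows a step of this kind, so the expectation rests on the change alone: the step of a 1.2-fold lower number from compound 2 to compound 4 (0.07 log units; within the scatter) is expected to be none beyond the scatter. Compound 4 is estimated at 2800 nM in this assay, expected to fall between 1000 nM and 8000 nM.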

Compound 4, concentration for 50% growth inhibition: > 30000 nM
Compound 4: a limit, no number; the forecaster's own chance of this, stated with the estimate: 5%; middle value at least 10-fold (1.02 log units) from the limit.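

Cyclohexyl in place of cyclopentyl at this chain position is not a silent change in this assay: the step is an at least 9.0-fold higher number from compound 2 to compound 4 (0.95 log units; beyond the scatter). For the compounds shown here, no earlier pair tested this position, and here a change confined to the ring at the chain end moves the result beyond the scatter. The true size of the step cannot be read, as compound 4 gives > 30000 nM, a limit of the assay and not a number: the limit of > 30000 nM in this assay, at which 2 of the 4 values shown sit.

Open, on these data alone, is how a smaller cyclobutyl ring, a larger cycloheptyl ring or an amine at this chain position would read. Also open, as far as these compounds go, is whether the step holds with other groups elsewhere on the shared core.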